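Swapping a chlorophenyl for a methoxyphenyl on the shared core

This account rests on a few compounds, and the source may have more. Where it says the series, first, only, none or still open, it means among the compounds named here.

Of the compounds shown here, three built on a shared core have been tested in an ADME assay on HepG2 cells (Homo sapiens) for cytotoxicity, read by luminescence, CellTiter-Glo and ATP content, with a stated time of 72 h; a lower number here means that less compound is needed, a higher number that more compound is needed for the effect. Compound 1 `CCC(CC)c1ccc2c(NCCCNCc3cc(F)ccc3OC)ccnc2c1` gives 7860 nM. Compound 2 `COc1ccccc1Oc1ccc2c(NCCCNCc3ccco3)ccnc2c1` gives 6500 nM. Compound 3 `COc1ccc(F)cc1CNCCCNc1ccnc2cc(Oc3ccc(Cl)cc3)ccc12` gives 4500 nM, the lowest of the three numbers, though its distances to compound 2 and to compound 1 both fall within the usual scatter, so the three cannot be ranked with confidence. Going by the values given here, the one step measured directly, a 1.7-fold lower number from compound 1 to compound 3 (0.24 log units; within the scatter), shows that exchanging a side group on the core left the number essentially where it was.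

Compound 4 `COc1ccc(F)cc1CNCCCNc1ccnc2cc(Oc3ccccc3OC)ccc12` has not yet been measured. It differs from compound 3 in one place: 2-methoxyphenyl in place of 4-chlorophenyl on an oxygen on an aromatic ring. Compound 2 already carries the 2-methoxyphenoxy group, although the rest of its structure also differs, and its number sits close to that of compound 3. Among the compounds with values here, with the only measured step within the scatter and compound 2 close by, compound 4 is expected to show no step beyond the scatter, a 1.3-fold higher number from compound 3 to compound 4 (0.12 log units; within the scatter). The estimate for compound 4 is 6000 nM, with a range from 3000 nM to 12000 nM.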

Compound 4, half-maximal effective concentration: 6400 nM
Beside the measured number, compound 4's estimate is 1.1-fold (0.03 log units) below it, within the range that was stated.
By their numbers in this assay, from the lowest: compounds 3, 4, 2 and 1 (each within the scatter of the next).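

In this assay, going by these compounds alone, this is the first direct reading at the oxygen on an aromatic ring, and exchanging 4-chlorophenyl for 2-methoxyphenyl there gives a 1.4-fold higher number from compound 3 to compound 4 (0.15 log units; within the scatter), so the two groups cannot be told apart at this position. With the 2-methoxyphenoxy group held in place, 5-fluoro-2-methoxyphenyl in place of furan-2-yl on the saturated chain carbon gives a 1.0-fold lower number from compound 2 to compound 4 (0.01 log units; within the scatter), which means that this second site also shows no step beyond the scatter. The comparison of 2-methoxyphenoxy with pentan-3-yl on an aromatic carbon, a 1.2-fold lower number from compound 1 to compound 4 (0.09 log units; within the scatter), points the same way, since all three new steps lie within the scatter.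

The compounds shown leave open whether a carboxylic acid or an amine on the ring at this position would move the number beyond the scatter. No measurement available here explains why these exchanges leave the numbers so close together.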